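The source may report more compounds than this note shows. Statements on the series, on what has been measured and on what is new or still open speak of the compounds shown alone.

Two compounds carry the shared core. Compound 1 `COc1ccc(CNC(=O)CC2c3ccccc3N=C(N(C)CCCCCN(C)C)N2c2ccc(-c3ccccc3)cc2)cc1` gives 4460 nM in a functional assay on SK-OV-3 cells (Homo sapiens) for cytotoxicity, read by MTT assay, with a stated time of 48 h (a higher number here means a weaker inhibitor, a lower number a stronger inhibitor), and compound 2 `Cc1ccc(CNC(=O)CC2c3ccccc3N=C(N3CCN(CCN(C)C)CC3)N2c2ccc(-c3ccccc3)cc2)cc1` gives 2330 nM in the same assay; the two numbers sit within the scatter of each other, so neither stands apart. Compound 3 `CN(C)CCN1CCN(C2=Nc3ccccc3C(CC(=O)NCc3ccccn3)N2c2ccc(-c3ccccc3)cc2)CC1` arises from compound 2 by one change: pyridin-2-yl in place of 4-methylphenyl on a saturated chain carbon bound to an amide-type nitrogen. For the measured compounds named here, no measured pair shows this change, so its effect is unknown. The step from compound 2 to compound 3 is expected to stay small, a 1.3-fold higher number from compound 2 to compound 3 (0.11 log units; within the scatter), with no clear direction beyond the scatter. Compound 3 is therefore estimated at 3000 nM, within a range of 1200 nM to 8000 nM.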

Compound 3, half-maximal inhibitory concentration: 5080 nM
The estimate for compound 3 lay 1.7-fold (0.23 log units) below the measured number; low and high end bracket the measured number.
By their numbers in this assay, from the lowest: compounds 2, 1 and 3 (each within the scatter of the next, the first and the last beyond it).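

On the saturated chain carbon bound to an amide-type nitrogen, pyridin-2-yl in place of 4-methylphenyl gives a 2.2-fold higher number from compound 2 to compound 3 (0.34 log units; beyond the scatter) in this assay and so weakens the compound modestly. For the compounds shown here, this is the first measured sign that the group at this position affects the read-out, a point the earlier compounds could not show. Nothing available explains the shift.

The step changes the ring nitrogen and the methyl together, so it cannot separate the two. Unsubstituted phenyl, pyridin-3-yl and pyridin-4-yl at this position remain open.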